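Solubility Expected from a Lactam Amide Swap

The compounds below may be only part of what the source reports. "The series", "measured", "known", "first", "only" and "open" are said of these compounds alone.

Compound 1 `Cn1ccc2ccc(-c3cc(Nc4ccccc4S(=O)(=O)N4CCOCC4)cc4nccnc34)cc21`: 5 ug/mL
Compound 2 `CN(Cc1cncnc1)S(=O)(=O)c1ccccc1Nc1cc(-c2ccc3ccn(C)c3c2)c2nccnc2c1`: 3 ug/mL
Compound 3 `Cn1cc(NC(=O)c2ccncc2Nc2cc(-c3ccc4ccn(C)c4c3)c3nccnc3c2)cn1`: 2 ug/mL

In a physicochemical assay for solubility, read by spectrophotometry, measured as kinetic solubility, at pH 8, tested at 500 uM (a higher number here means a more soluble compound, a lower number a less soluble compound), compound 3 gives 2 ug/mL. That number lies within the scatter of compound 2 at 3 ug/mL, and it is lower, beyond the scatter, than compound 1 at 5 ug/mL.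

Compound 4 `Cn1ccc2ccc(-c3cc(Nc4cnccc4C(=O)NC4CCNC(=O)C4)cc4nccnc34)cc21` carries 2-oxopiperidin-4-yl in place of 1-methyl-1H-pyrazol-4-yl on an amide-type nitrogen.

Among the compounds with values here, only one measured step is available, a 1.7-fold lower number from compound 1 to compound 2 (0.22 log units; within the scatter). It stayed within the scatter, but it exchanged a different group on a sulfonyl sulfur, so it bears on this change only loosely. Within the data shown here, no measured pair tests a change on the amide-type nitrogen.

A small rise in this assay is therefore expected, with no step beyond the scatter. The estimated step is a 1.5-fold higher number from compound 3 to compound 4 (0.18 log units; within the scatter). For compound 4 the expected value is 3 ug/mL, with an estimated range of 1 ug/mL to 10 ug/mL.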

Compound 4, solubility: 242 ug/mL
Estimate against measurement, compound 4: 81-fold (1.91 log units) below; measured number above the stated range.
By their numbers in this assay, from the lowest: compounds 3, 2 and 1 (each within the scatter of the next, the first and the last beyond it); then compound 4.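

In this assay, the group on the amide-type nitrogen proves to be a place where one change can move the number greatly: 2-oxopiperidin-4-yl in place of 1-methyl-1H-pyrazol-4-yl gives a 120-fold higher number from compound 3 to compound 4 (2.08 log units; beyond the scatter) with the rest of the structure unchanged. Within the data shown here, the only earlier step, a 1.7-fold lower number from compound 1 to compound 2 (0.22 log units; within the scatter), stayed within the scatter and lay on a sulfonyl sulfur, so it gave no sign of a shift of this size. The two groups differ at once in ring size, aromatic character and hydrogen-bond donors, and nothing measured here ties the rise to any one of these.

The compounds shown leave open whether the lactam carbonyl is needed, which a plain piperidine or a tetrahydropyran on the same nitrogen would test. They also leave open whether an open-chain amide would do as well as the ring.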